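From 4-methylphenyl to 4-bromophenyl

The compounds below may be only part of what the source reports. "The series", "measured", "known", "first", "only" and "open" are said of these compounds alone.

In a functional assay on MDA-MB-231 cells (Homo sapiens) for antiproliferative activity, read by MTT assay, with a stated time of 72 h (on this read-out lower numbers stand for stronger inhibition and higher numbers for weaker inhibition), compound 1 `COc1cc(-c2nccn2Cc2ccccc2)cc(OC)c1OC` gives > 100000 nM, which is a limit of the assay and not a number. For the measured compounds named here, compound 2 `COc1cc(-c2nccn2-c2ccc(C)cc2)cc(OC)c1OC` gives 4100 nM, the only true number so far. Compound 3 `COc1cc(-c2nccn2-c2ccc(Br)cc2)cc(OC)c1OC` carries bromo in place of methyl on an aromatic carbon. Going by the values given here, the one measured step is large: an at least 24-fold lower number from compound 1 to compound 2 (1.38 log units; beyond the scatter). Its size is open-ended, as shown by the limit of > 100000 nM in this assay, at which 1 of the 2 values shown sits. That step exchanged the whole group on the aromatic nitrogen, whereas the new change replaces a single substituent on the 4-methylphenyl, so it bears on this change only weakly. No step beyond the scatter is therefore expected in this assay, in either direction. The expected step is a 1.2-fold lower number from compound 2 to compound 3 (0.07 log units; within the scatter). For compound 3 the estimate is 3500 nM, with an expected range of 1200 nM to 12000 nM.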

Compound 3, half-maximal inhibitory concentration: 8400 nM
Compound 3: the middle estimate sits 2.4-fold (0.38 log units) below what was measured; measured number inside the range.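

The substituent on the aromatic carbon para to a large group does register in this assay: bromo in place of methyl gives a 2.0-fold higher number from compound 2 to compound 3 (0.31 log units; beyond the scatter), a modest step, so this position is not indifferent to the exchange. The advantage over benzyl on the aromatic nitrogen persists with the new substituent, as 4-bromophenyl in place of benzyl gives an at least 11-fold lower number from compound 1 to compound 3 (1.07 log units; beyond the scatter), so that earlier step is not tied to 4-methylphenyl alone. Compound 1 stands at a limit of the assay and not a number, so the size of this step remains open-ended: the limit of > 100000 nM in this assay, at which 1 of the 3 values shown sits.

With only methyl and bromo shown at this position, the compounds do not show how a methoxy group, an amine or a carboxylic acid would fare there. On these data alone, whether the direction of the bromo step would hold on a different core also remains open.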